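The compounds below may be only part of what the source reports. "The series", "measured", "known", "first", "only" and "open" are said of these compounds alone.

Compound 1 `CCCc1nc(-c2ccccc2)c(CNCCN2CCN(c3cccc(C)c3)CC2)o1` gives 43.1% in an assay on HEK293 cells for inhibition of Voltage-dependent T-type calcium channel subunit alpha-1G (Homo sapiens), read by fluorescence, tested at 10 uM (on this read-out lower numbers stand for less inhibition and higher numbers for more inhibition at the one concentration tested (going by the name of the read-out)), the smallest of the three numbers shown. Compound 3 `CCCc1nc(-c2ccccc2)c(CNCCCN2CCN(c3cccc(C(F)(F)F)c3)CC2)o1` gives 51.6%, which lies within the scatter of compound 1, while compound 2 `CCCc1nc(-c2ccccc2)c(CNCCCN2CCN(c3ccc(F)cc3)CC2)o1` gives 62.5%, beyond it. Compound 4 `CCCc1nc(-c2ccccc2)c(CNCCN2CCN(c3cccc(OC)c3)CC2)o1` differs from compound 1 by methoxy in place of methyl on an aromatic carbon. Going by the values given here, the only measured step that alters the group on that ring is a number 10.9 percentage points lower from compound 2 to compound 3 (beyond the scatter), a modest change on a longer linker; no measured step swaps methyl for methoxy, so the basis is thin. A small step, or none beyond the scatter, is therefore expected: a number 1.9 percentage points higher from compound 1 to compound 4 (within the scatter). Compound 4 is estimated at 45%, with a range from 25% to 65%.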

Compound 4, a percentage reported as inhibition, at one concentration (the size of the read-out at that concentration, not a potency): 40.2%
Estimate against measurement, compound 4: 4.8 percentage points above; the measured number falls inside the stated range.
By their numbers in this assay, from the lowest: compounds 4, 1 and 3 (each within the scatter of the next, the first and the last beyond it); then compound 2.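

In this assay, methoxy in place of methyl on an aromatic carbon, meta to a large group, gives a number 2.9 percentage points lower from compound 1 to compound 4 (within the scatter), the first direct test of this swap. At this position, the added oxygen and its hydrogen-bond acceptor leave the two compounds indistinguishable in this assay. Nothing measured here bears on why they read alike. From the compounds shown here alone, whether an amine or a carboxylic acid at this position would shift the number beyond the scatter remains open, as does whether the same swap reads alike on the longer linker of compound 2 and compound 3.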